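A chlorothiophene replaces the isobutylphenyl arm

The source may report more compounds than this note shows. Statements on the series, on what has been measured and on what is new or still open speak of the compounds shown alone.

Compound 3 `CC(C)Cc1ccc(-c2cc(C(=O)N3CCC(Cc4ccccc4)CC3)c3ccccc3n2)cc1` is one of three close relatives examined in an ADME assay on HepG2 2.2.15 cells (Homo sapiens) for cytotoxicity, read by MTT assay, with stated times of 3 days and 7 days; a higher number here means that more compound is tolerated, a lower number that less compound is tolerated. In this assay compound 3 gives > 20000 nM, which is a limit of the assay and not a number. Compound 1 `Cc1cccc(-c2cc(C(=O)N3CCC(Cc4ccccc4)CC3)c3ccccc3n2)c1` gives > 20000 nM, likewise a limit. Compound 2 `Cc1ccc(-c2cc(C(=O)N3CCC(Cc4ccccc4)CC3)c3ccccc3n2)cc1` gives > 20000 nM, again a limit. All three values sit at the same limit (the limit of > 20000 nM in this assay, at which 3 of the 3 values shown sit), and the steps among them, a step that the two limits leave unreadable from compound 1 to compound 2, a step that the two limits leave unreadable from compound 1 to compound 3 and a step that the two limits leave unreadable from compound 2 to compound 3, cannot be read in size or direction. On these numbers compound 3 stands where both of its relatives stand: at the limit, with no measurable separation from either.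

Compound 4 `O=C(c1cc(-c2ccsc2Cl)nc2ccccc12)N1CCC(Cc2ccccc2)CC1` differs from compound 3 in one place: 2-chlorothiophen-3-yl in place of 4-isobutylphenyl on an aromatic carbon. For the measured compounds named here, none of the measured steps carries a readable size that bears on this change; every step among compounds 1, 2 and 3 ends at the limit. Nothing in the measured set moves this assay off its limit, and the expectation for compound 4 in this assay is no step beyond the scatter, most likely another limit. The expected step is a step that the limit leaves unreadable from compound 3 to compound 4. Compound 4 is accordingly estimated at 30000 nM, within a range from 15000 nM to 60000 nM, with a limit the most probable report.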

Compound 4, half-maximal cytotoxic concentration: > 20000 nM
Compound 4: only a limit was reported (the forecaster's own chance of this, stated with the estimate: 80%); the middle value does not contradict the limit.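

For the compounds shown here, compound 4 also returns only a limit in this assay, so no step from compound 1, compound 2 or compound 3 to compound 4 can be read in size or direction, and all four compounds rest at the same limit: the limit of > 20000 nM in this assay, at which 4 of the 4 values shown sit. The compounds shown leave open where the half-maximal cytotoxic concentration of any of the four lies, and whether the aryl arms differ in this assay at all.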